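The source may hold more compounds than are shown below. What is called first, only, known or untested is meant among the compounds shown, and "the series" means these compounds.

For the measured compounds named here, compound 1 `Cc1cccc(C)c1Oc1ccc([N+](=O)[O-])c(Nc2ccc(C#N)cc2)c1` is the only member of the series with a number in an ADME assay on H9 cells (Homo sapiens) for cytotoxicity, read by XTT assay, with a stated time of 6 days (a higher number here means that more compound is tolerated, a lower number that less compound is tolerated), where compound 1 gives 69600 nM. Compound 2 `Cc1cc(C#N)cc(C)c1Oc1ccc([N+](=O)[O-])c(Nc2ccc(C#N)cc2)c1` gives in this assay only a limit, > 65100 nM. The step that the limit leaves unreadable from compound 1 to compound 2 is therefore not readable, since the limit of > 65100 nM in this assay, at which 1 of the 2 values shown sits, is all that is shown for compound 2. Compound 3 `Cc1cccc(C)c1Oc1cc(Nc2ccc(C#N)cc2)c([N+](=O)[O-])cc1[N+](=O)[O-]` differs from compound 1 by nitro in place of hydrogen on an aromatic carbon. Going by the values given here, no measured step bears on this change, so no shift beyond the scatter is expected, and the step of a 1.1-fold lower number from compound 1 to compound 3 (0.03 log units; within the scatter) is the estimate. For compound 3 the expected value in this assay is 65000 nM, with a range of 25000 nM to 150000 nM.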

Compound 3, half-maximal cytotoxic concentration: > 61800 nM
Compound 3 gave a limit, no number; the forecaster's own chance of this, stated with the estimate: 45%; the middle value lies beyond the limit too.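

In this assay compound 3 gives > 61800 nM as a limit and not a number, so the step from compound 1 to compound 3 cannot be read. The compounds shown leave open whether cyano or nitro in place of hydrogen moves the tolerated concentration at all.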